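Trimming the Aniline Ring: What to Expect for Compound 3

This account rests on a few compounds, and the source may have more. Where it says the series, first, only, none or still open, it means among the compounds named here.

Measured compounds:
compound 1, `C#Cc1cccc(Nc2ncnc3cc(OC)c(OCCCCC(=O)Nc4ccc(S(N)(=O)=O)cc4)cc23)c1`, 7720 nM in a functional assay on A549 cells (Homo sapiens) for antiproliferative activity, read by MTT assay, with a stated time of 72 h; a higher number here means a weaker inhibitor, a lower number a stronger inhibitor
compound 2, `CCc1ccc(Nc2ncnc3cc(OC)c(OCCCCC(=O)Nc4ccc(S(N)(=O)=O)cc4)cc23)cc1`, 12100 nM in this assay

For the measured compounds named here, compound 2 holds the higher of the two numbers so far, but its only neighbour, compound 1, sits close: the step of a 1.6-fold higher number from compound 1 to compound 2 (0.20 log units; within the scatter) is within the scatter, so the two cannot be ordered. Compound 3, `COc1cc2ncnc(Nc3ccccc3)c2cc1OCCCCC(=O)Nc1ccc(S(N)(=O)=O)cc1`, differs from compound 2 by hydrogen in place of ethyl on an aromatic carbon, that is, 4-ethylphenyl to phenyl, or (4-ethylphenyl)amino to anilino. Going by the values given here, no measured step removes a substituent from this ring; the one step available, a 1.6-fold higher number from compound 1 to compound 2 (0.20 log units; within the scatter), moves between two differently placed groups and is itself within the scatter, so it gives no direction for the loss of the ethyl. On this basis compound 3 is expected to stay near compound 2, with a step of a 1.2-fold higher number from compound 2 to compound 3 (0.06 log units; within the scatter) that is not expected to exceed the scatter. The estimate for compound 3 in this assay is therefore 14000 nM, within a range of 5500 nM to 35000 nM.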

Compound 3, half-maximal inhibitory concentration: > 40000 nM
Compound 3: no number, only a limit; the forecaster's own chance of this, stated with the estimate: 10%; middle value at least 2.8-fold (0.45 log units) away from the limit.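

In this assay compound 3 gives a limit of the assay and not a number: the limit of > 40000 nM in this assay, at which 1 of the 3 values shown sits.
Taking away the ethyl, para to a large group, gives an at least 3.3-fold higher number from compound 2 to compound 3 (0.51 log units; beyond the scatter), and taking away the ethynyl gives an at least 5.1-fold higher number from compound 1 to compound 3 (0.71 log units; beyond the scatter). The earlier pair showed only that ethyl and ethynyl, placed differently on the aniline ring, could not be ordered; the new steps show that the ring with neither group gives the weaker result in both comparisons, so a substituent on this ring counts in this series.

As far as these compounds go, whether a methyl, a chlorine, a methoxy or an amine at the same place would serve as ethyl does remains open. From the compounds shown here alone, how far compound 3 actually lies past its limit also remains open, so the full size of both steps is unknown.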